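Swapping the Sulfonyl Substituent: Stability Stays Put

The source may hold more compounds than are shown below. What is called first, only, known or untested is meant among the compounds shown, and "the series" means these compounds.

Three compounds share one core and differ only in the group on a sulfonyl sulfur. Compound 1 `O=C(NS(=O)(=O)c1ccc(F)cc1)c1ccc(Nc2nc(NC3(c4ccc(Cl)cc4)CC3)nc(OCC(F)(F)F)n2)cc1` carries a 4-fluorophenyl there; in an ADME assay on microsomes from liver (Homo sapiens) for metabolic stability, with a stated time of 10 min (on this read-out higher numbers stand for a more stable compound and lower numbers for a less stable compound), compound 1 gives 100%. Compound 2 `CC(C)S(=O)(=O)NC(=O)c1ccc(Nc2nc(NC3(c4ccc(Cl)cc4)CC3)nc(OCC(F)(F)F)n2)cc1` carries an isopropyl, and in this assay compound 2 gives 100%. Compound 3 `O=C(NS(=O)(=O)C1CC1)c1ccc(Nc2nc(NC3(c4ccc(Cl)cc4)CC3)nc(OCC(F)(F)F)n2)cc1` carries a cyclopropyl, and in this assay compound 3 gives 100%, which places it level with compounds 1 and 2 at the digits shown. The steps among them were flat: no change at the digits printed from compound 1 to compound 2 (within the scatter), no change at the digits printed from compound 1 to compound 3 (within the scatter) and no change at the digits printed from compound 2 to compound 3 (within the scatter).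

Compound 4 `CN(C)S(=O)(=O)NC(=O)c1ccc(Nc2nc(NC3(c4ccc(Cl)cc4)CC3)nc(OCC(F)(F)F)n2)cc1` is not yet measured. It differs from compound 3 in one place: dimethylamino in place of cyclopropyl on a sulfonyl sulfur. All three measured steps swap the group on that same sulfonyl sulfur, and they are the ones that bear on this change; none of them moved this assay beyond the scatter. Within the data shown here, a nitrogen-linked group, such as the entering dimethylamino, has not been tried at that spot here, so that part of the change rests on no direct precedent. The expected step is nonetheless small: a number 4 percentage points lower from compound 3 to compound 4 (within the scatter), which is expected to stay within the scatter. Compound 4 is estimated to give 96%, with a likely range from 82% to 100%.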

Compound 4, percent of the compound remaining: 86%
Compound 4: middle estimate off by 10 percentage points, on the high side; low and high end bracket the measured number.
By their numbers in this assay, from the lowest: compound 4; then compounds 1, 2 and 3 (each within the scatter of the next).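

The group on this sulfonyl sulfur is not as free to change as the first three compounds suggested: in this assay, dimethylamino gives a number 14 percentage points lower from compound 3 to compound 4 (beyond the scatter), and the same comparison with the other two groups gives a number 14 percentage points lower from compound 2 to compound 4 (beyond the scatter) and a number 14 percentage points lower from compound 1 to compound 4 (beyond the scatter). The 4-fluorophenyl, isopropyl and cyclopropyl groups, which all join the sulfur through carbon, stay level, so the first group joined through nitrogen is also the first to move this read-out beyond the scatter, although a single compound cannot establish a rule. Cyclopropyl and dimethylamino have the same heavy-atom count, so that count does not separate them, and no supporting data here explain the lower number.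

Going by these compounds, it remains open whether this step belongs to nitrogen-linked groups in general or to dimethylamino alone, a question that a pyrrolidine, a morpholine or a methylamino group on the same sulfonyl sulfur would help to answer. Among these compounds, it also remains open whether swapping cyclopropyl for dimethylamino would give a similar step on a core other than the one shared by these compounds.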